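Piperidine Amide Replaces Cyclopropyl Amide on Compound 2

This account rests on a few compounds, and the source may have more. Where it says the series, first, only, none or still open, it means among the compounds named here.

Measured compounds: compound 1 `Cn1cc(Nc2nn(Cc3ccc(C(=O)NC4CCCCC4)cc3)c(=O)c3ccccc23)cn1` and compound 2 `Cc1noc(C)c1-c1nn(Cc2ccc(C(=O)NC3CC3)cc2)c(=O)c2ccccc12`.

In a functional assay on HCT-116 cells (Homo sapiens) for antiproliferative activity, read by MTT assay, with a stated time of 72 h (a higher number here means a weaker inhibitor, a lower number a stronger inhibitor), compound 1 gives 5400 nM. For compound 2 only a limit is known, > 100000 nM, not a number (the limit of > 100000 nM in this assay, at which 1 of the 2 values shown sits). Compound 3 `Cc1noc(C)c1-c1nn(Cc2ccc(C(=O)NC3CCN(C)CC3)cc2)c(=O)c2ccccc12` differs from compound 2 by 1-methylpiperidin-4-yl in place of cyclopropyl on an amide-type nitrogen. For the measured compounds named here, no measured step links these two compounds, and compound 2 itself sits at a limit, so the size of the change in this assay is open; a modest move toward a stronger inhibitor is expected, with an at least 1.6-fold lower number from compound 2 to compound 3 (0.22 log units; that floor lies within the scatter) as the expected step. Compound 3 is expected near 60000 nM, between 8000 nM and 200000 nM.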

Compound 3, half-maximal inhibitory concentration: 84900 nM
For compound 3 the middle estimate is 1.4-fold (0.15 log units) below the measured one, within the range that was stated.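

At this amide nitrogen, 1-methylpiperidin-4-yl gives a value that can be read in this assay, and the change from cyclopropyl amounts to an at least 1.1-fold lower number from compound 2 to compound 3 (0.07 log units; that floor lies within the scatter). That floor does not establish a real gain in activity. Compound 2 stands at a limit, so the step has no upper bound and its true size stays unknown: the limit of > 100000 nM in this assay, at which 1 of the 3 values shown sits.

Still open, from the compounds shown here alone, is whether the ring nitrogen or simply the larger ring goes with this change. A tetrahydropyran-4-yl group, with oxygen in place of that nitrogen, on the same amide would bear on this question.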